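This account rests on a few compounds, and the source may have more. Where it says the series, first, only, none or still open, it means among the compounds named here.

Measured in an ADME assay on HepG2 cells (Homo sapiens) for cytotoxicity; a lower number here means that less compound is needed, a higher number that more compound is needed for the effect:
- Compound 1 `Cc1ccc(S(=O)(=O)N[C@@H](CC(=O)NC(C)(C)C)C(=O)NCCNC(=O)c2cc(Cl)ccn2)cc1`: > 11000 nM, a limit
- Compound 2 `Cc1ccc(S(=O)(=O)N[C@@H](CC(=O)NC(C)(C)C)C(=O)NCCNC(=O)c2ccc(Cl)cc2)cc1`: > 11000 nM, a limit

Compound 2 stands at a limit and has no exact number. The other value available, for compound 1, is a limit too. Both compounds share one limit: the limit of > 11000 nM in this assay, at which 2 of the 2 values shown sit.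

Compound 3 `Cc1ccc(S(=O)(=O)N[C@@H](CC(=O)NC(C)(C)C)C(=O)NCCNS(=O)(=O)c2ccccc2)cc1` keeps the core of compound 2, but phenylsulfonyl takes the place of (4-chlorophenyl)carbonyl on an amine nitrogen: phenylsulfonyl in place of (4-chlorophenyl)carbonyl on an amine nitrogen.

Within the data shown here, only one measured step bears on this change, and it is a different replacement: a step that the two limits leave unreadable from compound 1 to compound 2. It offers no size to carry over, so it cannot set the scale of the new step. With compound 2 at > 11000 nM, the reasonable expectation in this assay is no step beyond the scatter and no firm direction. Compound 3 may well be reported as a limit again.

The estimated change is a step that the limit leaves unreadable from compound 2 to compound 3, and it is only a rough figure.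

For compound 3 the expected value is 14000 nM, with an estimated range from 7000 nM to 30000 nM.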

Compound 3, half-maximal effective concentration: > 11000 nM
Compound 3 was reported as a limit (the forecaster's own chance of this, stated with the estimate: 85%); the middle value lies beyond the limit too.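

Compound 3 is again reported only as a limit, so neither the change from compound 2 to compound 3 nor that from compound 1 to compound 3 can be read as a step: the limit of > 11000 nM in this assay, at which 3 of the 3 values shown sit.

The compounds shown leave open how much of compound 1, compound 2 or compound 3 is needed for an effect in this assay, and whether they differ there at all.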